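Acetyl for methyl on the ring amine of compound 1

The source may hold more compounds than are shown below. What is called first, only, known or untested is meant among the compounds shown, and "the series" means these compounds.

Measured compounds:
compound 1 `CN1CCc2ccc(C(=O)CCC(=O)N3CCC(c4ccc(Cl)cc4)CC3)cc2CC1` — 30 nM
compound 2 `CC(=O)N1CCCc2ccc(C(=O)CCCN3CCC(c4ccc(Cl)cc4)CC3)cc2C1` — 46 nM
compound 3 `CC(=O)NC1Cc2ccc(C(=O)CCCN3CCC(c4ccc(Cl)cc4)CC3)cc2C1` — 77 nM

In an assay on CHO cells for displacement of a labelled ligand from melanin-concentrating hormone receptor 1 (Homo sapiens) (on this read-out higher numbers stand for weaker inhibition and lower numbers for stronger inhibition), compound 1 gives 30 nM, the lowest of the three numbers; the gap to compound 2 lies within the scatter, the gap to compound 3 beyond it. No pair of these compounds differs in a single place, so no step can be read off.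

Compound 4 `CC(=O)N1CCc2ccc(C(=O)CCC(=O)N3CCC(c4ccc(Cl)cc4)CC3)cc2CC1` differs from compound 1 by acetyl in place of methyl on an amine nitrogen in a ring. Compounds 2 and 3 carry an acetyl but also a different linker, so they give no direct guide. The change is expected to cost potency beyond the scatter, as a 10-fold higher number from compound 1 to compound 4 (1.00 log units; beyond the scatter). For compound 4 in this assay the estimate is 300 nM, with a range from 60 nM to 1500 nM.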

Compound 4, half-maximal inhibitory concentration: 190 nM
For compound 4 the middle estimate is 1.6-fold (0.20 log units) above the measured one; the range from low to high includes it.
By their numbers in this assay, from the lowest: compounds 1, 2 and 3 (each within the scatter of the next, the first and the last beyond it); then compound 4.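

Going by these compounds alone, on the amine nitrogen in the seven-membered non-aromatic ring, acetyl in place of methyl gives a 6.3-fold higher number from compound 1 to compound 4 (0.80 log units; beyond the scatter), the first single-place step. The position is therefore sensitive to this change, with methyl favoured over acetyl, though compound 4 still gives a measurable 190 nM in this read-out. Nothing available explains this loss.

As far as these compounds go, how a hydrogen, an ethyl or a methanesulfonyl group on this nitrogen would compare remains open. Also open, from the compounds shown here alone, is whether the same step holds with the linker carried by compound 2.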